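The source may hold more compounds than are shown below. What is called first, only, known or untested is meant among the compounds shown, and "the series" means these compounds.

Three close relatives of one shared core have been tested in a functional assay on MDA-MB-231 cells (Homo sapiens) for cytotoxicity, read by MTT assay, with a stated time of 48 h; a higher number here means a weaker inhibitor, a lower number a stronger inhibitor. Compound 1 `COc1ccccc1Nc1nc(-c2cccc(F)c2)nc2ccc(F)cc12` gives > 50000 nM, which is a limit of the assay rather than a number. Compound 2 `Fc1cccc(-c2nc(Nc3ccc(Cl)cc3)c3cc(F)ccc3n2)c1` likewise gives > 50000 nM, again a limit. Compound 3 `Fc1cccc(-c2nc(Nc3ccc(Br)cc3)c3cc(F)ccc3n2)c1` gives > 50000 nM, also a limit. From the compounds shown here alone, because of the limit of > 50000 nM in this assay, at which 3 of the 3 values shown sit, none of the steps between these compounds can be read: a step that the two limits leave unreadable from compound 1 to compound 2, a step that the two limits leave unreadable from compound 1 to compound 3 and a step that the two limits leave unreadable from compound 2 to compound 3 each join two limits, so their size stays unknown. Compound 3 therefore stands only at the limit, alongside the two other values, with no number of its own.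

Compound 4 `Nc1cccc(Nc2nc(-c3cccc(F)c3)nc3ccc(F)cc23)c1` differs from compound 3 in one place: 3-aminophenyl in place of 4-bromophenyl on a nitrogen on an aromatic ring. No measured step bears on this exchange, since every step shown connects two limits and has no readable size or direction. Any expectation for compound 4 can rest only on the fact that all three measured compounds sit at the limit. The step expected here is a step that the limit leaves unreadable from compound 3 to compound 4, with no direction that can be read from the data. Compound 4 is therefore expected to give about 60000 nM in this assay, within a range from 10000 nM to 300000 nM, and most likely to be reported once more only as a limit.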

Compound 4, half-maximal inhibitory concentration: > 50000 nM
Compound 4: a limit, no number; the forecaster's own chance of this, stated with the estimate: 80%; the middle value does not contradict the limit.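

Compound 4 gives only a limit in this assay, as do compound 1, compound 2 and compound 3, so none of the steps from those three to compound 4 can be read: the limit of > 50000 nM in this assay, at which 4 of the 4 values shown sit.

The compounds shown leave open how large any real difference among these four is, and whether any group on this nitrogen would give a readable number in this assay.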